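Swapping the aryl group on a thiazole CRTH2 antagonist

A few compounds are considered here, and "the series" means these few. Any claim that something is new, unique, unknown or untested is made for them only; others in the source may bear on it.

Measured compounds:
compound 1 `COc1ccc(C(c2ccccc2)c2nc(-c3ccc(Cl)cc3)c(CC(=O)O)s2)cc1` — 76 nM
compound 2 `COc1ccc(OC)c(-c2nc(C(c3ccccc3)c3ccccc3)sc2CC(=O)O)c1` — > 100000 nM
compound 3 `CS(=O)(=O)Nc1cccc(-c2nc(C(c3ccc(F)cc3)c3ccc(F)cc3)sc2CC(=O)O)c1` — 370 nM

Of the compounds shown here, three sharing one core have been tested in an in vitro functional assay on HEK285-7 cells for antagonist activity at prostaglandin D2 receptor 2 (Homo sapiens), read by BRET and beta-arrestin recruitment; on this read-out higher numbers stand for weaker inhibition and lower numbers for stronger inhibition. Compound 1 gives 76 nM and is the stronger of the two numbered results. Compound 2 returns only a limit, > 100000 nM, so no number is known for it. Compound 3 gives 370 nM, the higher of the two numbers shown, and the distance from compound 1 is beyond the usual scatter of the assay (the limit of > 100000 nM in this assay, at which 1 of the 3 values shown sits).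

Compound 4 `Nc1cc(-c2nc(C(c3ccc(F)cc3)c3ccc(F)cc3)sc2CC(=O)O)cc(F)n1` has not yet been measured. It differs from compound 3 in a single place: 2-amino-6-fluoropyridin-4-yl in place of 3-(methanesulfonamido)phenyl on an aromatic carbon. The rest of the molecule, including the carboxymethyl group and the bis(4-fluorophenyl)methyl group, is kept.

Among the measured compounds shown here, no measured pair in this set differs only at that position, so there is no direct yardstick. The change is expected to move the result only modestly, with a step from compound 3 to compound 4 of about a 1.4-fold higher number from compound 3 to compound 4 (0.13 log units; within the scatter) in this assay. Compound 4 is therefore estimated at 500 nM, within a range from 100 nM to 3000 nM.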

Compound 4, half-maximal inhibitory concentration: 1400 nM
The estimate for compound 4 lay 2.8-fold (0.45 log units) below the measured number, within the range that was stated.
By their numbers in this assay, from the lowest: compound 1; then compound 3; then compound 4. At a limit, above all of these: compound 2.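

In this assay, among the compounds shown here, putting 2-amino-6-fluoropyridin-4-yl in place of 3-(methanesulfonamido)phenyl gives a 3.8-fold higher number from compound 3 to compound 4 (0.58 log units; beyond the scatter), the first step in this set in which only one place changes. The result at this position, on the aromatic carbon next to the ring nitrogen and next to the ring atom that bears the carboxymethyl group, therefore depends on which aryl group sits there, even though both groups have the same counts of hydrogen-bond donors and acceptors and neither carries a net charge. No measurement shown gives a cause for this step.

From the compounds shown here alone, what stays open is which part of the swap carries the step, since the ring nitrogen, the fluorine, the amine and the loss of the methanesulfonamido group all arrive together. Going by these compounds, a phenyl ring bearing only an amine, or an aminopyridinyl group without the fluorine, would help to separate these parts, and the readings for a carboxylic acid or a longer alkyl chain on the aryl ring also remain unknown.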